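Methyl on the core ring of the oxazole analogue

The compounds below may be only part of what the source reports. "The series", "measured", "known", "first", "only" and "open" are said of these compounds alone.

Three compounds of the series have been run in a functional assay on CHO cells for agonist activity at Free fatty acid receptor 1 (Homo sapiens), read by FLIPR and calcium flux; on this read-out higher numbers stand for an effect only at larger amounts of compound and lower numbers for an effect already at smaller amounts. Compound 1 `CC(C)c1ccccc1-c1cccc(COc2ccc(S(=O)(=O)CC(=O)O)cc2)c1` gives 74.1 nM. Compound 2 `Cc1ccc(C)n1-c1cccc(COc2ccc(S(=O)(=O)CC(=O)O)cc2)c1` gives 129 nM, and compound 3 `Cc1noc(C)c1-c1cccc(COc2ccc(S(=O)(=O)CC(=O)O)cc2)c1` gives 269 nM. Among these, compound 3 has the highest number: the step of a 2.1-fold higher number from compound 2 to compound 3 (0.32 log units; beyond the scatter) is modest, and the step of a 3.6-fold higher number from compound 1 to compound 3 (0.56 log units; beyond the scatter) is also modest, while the step of a 1.7-fold higher number from compound 1 to compound 2 (0.24 log units; within the scatter) stays within the scatter. All three steps exchange the group on the pendant aromatic carbon.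

Compound 4 `Cc1ccc(-c2c(C)noc2C)cc1COc1ccc(S(=O)(=O)CC(=O)O)cc1` is compound 3 with one change: methyl in place of hydrogen on an aromatic carbon. Going by the values given here, no measured step in this set involves a methyl in place of hydrogen on the core; the three known steps exchange the whole pendant group and therefore give no direct reading on this change. With nothing in the series pointing either way, the expectation for compound 4 in this assay is a step of a 1.0-fold higher number from compound 3 to compound 4 (0.00 log units; within the scatter) that does not go beyond the scatter. The estimate for compound 4 is therefore 270 nM, with a range from 110 nM to 650 nM.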

Compound 4, half-maximal effective concentration: 427 nM
Estimate against measurement, compound 4: 1.6-fold (0.20 log units) below, within the range that was stated.
By their numbers in this assay, from the lowest: compounds 1 and 2 (each within the scatter of the next); then compounds 3 and 4 (each within the scatter of the next).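

Methyl in place of hydrogen on an aromatic carbon of the six-membered aromatic ring, ortho to a large group and para to the 3,5-dimethyl-1,2-oxazol-4-yl group, gives in this assay a 1.6-fold higher number from compound 3 to compound 4 (0.20 log units; within the scatter) and so leaves the read-out unchanged within the usual scatter. Going by these compounds alone, this is the first reading of the series on the shared core itself rather than on the pendant group, and it shows that this position can carry a methyl with no step that stands out from repeated measurement. Nothing available on these compounds speaks to the reason for this outcome.

The compounds shown leave open whether a fluorine, a methoxy group, an amine or a longer chain at the same aromatic carbon would also leave the number in place, since a single methyl says little about groups of other size or kind. They also leave open whether the same methyl gives a similar result when the pendant group is the 2-isopropylphenyl of compound 1 or the 2,5-dimethyl-1H-pyrrol-1-yl of compound 2.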